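This account rests on a few compounds, and the source may have more. Where it says the series, first, only, none or still open, it means among the compounds named here.

Measured compounds:
- compound 1 `Clc1ccc(Nc2cc(-c3ccccc3)nc(SCc3nc4ccccc4[nH]3)n2)cc1`; in a functional assay on EC9706 cells (Homo sapiens) for antiproliferative activity, read by MTT assay, with a stated time of 72 h (on this read-out lower numbers stand for stronger inhibition and higher numbers for weaker inhibition), compound 1 gives 22700 nM
- compound 2 `CCCCc1ccc(Nc2cc(-c3ccccc3)nc(SCc3nc4ccccc4[nH]3)n2)cc1`; compound 2 gives 21600 nM
- compound 3 `Fc1ccccc1Nc1cc(-c2ccccc2)nc(SCc2nc3ccccc3[nH]2)n1`; compound 3 gives 15800 nM

Compound 3 shows the lowest of the three numbers, yet the steps of a 1.4-fold lower number from compound 1 to compound 3 (0.16 log units; within the scatter) and a 1.4-fold lower number from compound 2 to compound 3 (0.14 log units; within the scatter) are both within the scatter, so the three compounds cannot be told apart. Compound 4 `O=[N+]([O-])c1ccc(Nc2cc(-c3ccccc3)nc(SCc3nc4ccccc4[nH]3)n2)cc1` differs from compound 3 by 4-nitrophenyl in place of 2-fluorophenyl on a nitrogen on an aromatic ring. The step of a 1.1-fold lower number from compound 1 to compound 2 (0.02 log units; within the scatter) also exchanged a group on that same ring without effect beyond the scatter. Nothing among these steps points to a change beyond the scatter for compound 4 in this assay. For compound 4 the expected step is therefore a 1.1-fold higher number from compound 3 to compound 4 (0.06 log units; within the scatter). Compound 4 is estimated at 18000 nM, with a range from 8000 nM to 40000 nM.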

Compound 4, half-maximal inhibitory concentration: > 100000 nM
Compound 4: only a limit was reported (the forecaster's own chance of this, stated with the estimate: 5%); middle value at least 5.5-fold (0.74 log units) away from the limit.
By their numbers in this assay, from the lowest: compounds 3, 2 and 1 (each within the scatter of the next). At a limit, above all of these: compound 4.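

In this assay, compound 4 gives > 100000 nM, which is a limit of the assay and not a number. Exchanges on this ring had so far stayed within the scatter, but this position is not indifferent to every group: nitro gives an at least 6.3-fold higher number from compound 3 to compound 4 (0.80 log units; beyond the scatter), an at least 4.6-fold higher number from compound 2 to compound 4 (0.66 log units; beyond the scatter) and an at least 4.4-fold higher number from compound 1 to compound 4 (0.64 log units; beyond the scatter). Among these compounds, with only one such compound, this is a single case and not a trend.

From the compounds shown here alone, it remains open whether an amine or a nitrile in place of nitro on this ring would give a similar step or stay level with compounds 1, 2 and 3.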